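This account rests on a few compounds, and the source may have more. Where it says the series, first, only, none or still open, it means among the compounds named here.

Working notes on the series. Two compounds have been run in an assay on CHO-K1 cells for inhibition of sodium-dependent dopamine transporter (Homo sapiens); on this read-out higher numbers stand for weaker inhibition and lower numbers for stronger inhibition. Compound 1 `CN1C[C@H]2CCCC[C@@]2(Cc2ccc(Cl)c(Cl)c2)C1` gives 479 nM in this assay. Compound 2 `Clc1ccc(C[C@]23CCCC[C@H]2CNC3)cc1Cl` gives 501 nM in this assay. Compound 2 holds the highest of the two numbers, but its nearest neighbour, compound 1, sits within the scatter of it, so the two values show no difference that can be read as order.

Compound 3 `CN1C[C@@H]2CCCC[C@]2(Cc2ccc(Cl)c(Cl)c2)C1` has not been measured. Compound 3 differs from compound 2 by methyl in place of hydrogen on an amine nitrogen in a ring, in words: methyl in place of hydrogen on an amine nitrogen in a ring. Among the compounds with values here, no step between measured compounds is available for this change, and the only comparison at hand is the closeness of compound 1 and compound 2 in this assay, which gives no sign of a large shift in either direction.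

The expected step from compound 2 to compound 3 is therefore a 1.2-fold lower number from compound 2 to compound 3 (0.08 log units; within the scatter), that is, nothing beyond the scatter. Compound 3 is estimated at 420 nM in this assay, with a range of 150 nM to 1200 nM.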

Compound 3, half-maximal inhibitory concentration: 490 nM
For compound 3 the middle estimate is 1.2-fold (0.07 log units) below the measured one, within the range that was stated.
By their numbers in this assay, from the lowest: compounds 1, 3 and 2 (each within the scatter of the next).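

In this assay, methyl in place of hydrogen on the amine nitrogen in the ring now has a step of its own, a 1.0-fold lower number from compound 2 to compound 3 (0.01 log units; within the scatter), which places this change within the scatter for this pair. The mirror-image pair gives a separate reading, a 1.0-fold higher number from compound 1 to compound 3 (0.01 log units; within the scatter), so inverting both stereocentres also shows nothing beyond the scatter in this assay. This second step is a comparison of configuration alone, with no change of group involved: the fact that compounds 1 and 3 differ only in the configuration as drawn

Still open, going by these compounds, is whether a longer chain or a benzyl group on the same ring nitrogen would stay within the scatter, as methyl does, or would give a step beyond it. Open too, on these data alone, is whether the mirror image of compound 2 would sit as close to compound 2 as compound 1 sits to compound 3.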